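Swapping Phenoxy for Dimethylamino in a Cytotoxicity Pair

The compounds below may be only part of what the source reports. "The series", "measured", "known", "first", "only" and "open" are said of these compounds alone.

Compound 1 `COc1cc(C)cc(-c2nn(CC#N)cc2-c2ccc(-c3cccc(C(C)=O)c3)nc2)c1`: in a functional assay on HT-29 cells (Homo sapiens) for cytotoxicity, read by sulforhodamine B assay, with a stated time of 48 h, tested at 10 uM (a lower number here means a stronger effect, a higher number a weaker effect of the compound at the concentration tested), compound 1 gives -11%.
Compound 2 `Cc1cc(O)cc(-c2nn(CC#N)cc2-c2ccnc(-c3ccc(Oc4ccccc4)cc3)c2)c1`: in this assay compound 2 gives -89%.

Compound 2 holds the lowest of the two numbers. Its nearest neighbour is compound 1, whose value lies higher by an amount beyond the scatter, so of this pair compound 2 shows the stronger effect. Within the data shown here, the two compounds differ in several places at once, and no single-change step connects them; their values show only that compound 2 acts more strongly.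

Compound 3 `Cc1cc(O)cc(-c2nn(CC#N)cc2-c2ccnc(-c3ccc(N(C)C)cc3)c2)c1` is not yet measured. It differs from compound 2 by dimethylamino in place of phenoxy on an aromatic carbon. Among the measured compounds shown here, the measured pair carries no step that bears on this change, so the expectation leans on the strong effect of compound 2 alone. Compound 3 is estimated at -55%, within -95% to 0%. The expected step of a number 34 percentage points higher from compound 2 to compound 3 (beyond the scatter) would be a moderate weakening, beyond the scatter but leaving a clear effect.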

Compound 3, a percentage reported as activity, at one concentration (the size of the read-out at that concentration, not a potency): -52%
Beside the measured number, compound 3's estimate is 3 percentage points below it; the measured number falls inside the stated range.
By their numbers in this assay, from the lowest: compound 2; then compound 3; then compound 1.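

Swapping phenoxy for dimethylamino on an aromatic carbon, para to a large group, gives in this assay a number 37 percentage points higher from compound 2 to compound 3 (beyond the scatter), so the read-out at this position depends clearly on the group it carries. The aromatic ring of phenoxy is still not needed for a clear effect, as compound 3 , which has no such ring in that group, gives -52% in the same assay. Nothing measured here explains this step.

From the compounds shown here alone, with only phenoxy and dimethylamino compared at this carbon, it remains open whether the ring, the oxygen or the nitrogen matters most for the difference. Methoxy, benzyloxy, or a morpholine ring at the same place would help separate these possibilities.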